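Swapping a Furan for a Thiophene on a Dichloroacetamide

A few compounds are considered here, and "the series" means these few. Any claim that something is new, unique, unknown or untested is made for them only; others in the source may bear on it.

Compound 1, `O=C(Nc1cccc(-c2ccoc2)c1)C(Cl)Cl`: 37600 nM
Compound 2, `COC(=O)c1ccc(-c2cccc(NC(=O)C(Cl)Cl)c2)cc1`: > 50000 nM

For the measured compounds named here, in a functional assay on NCI-H460 cells (Homo sapiens) for cytotoxicity, read by MTT assay, with a stated time of 68 h (on this read-out lower numbers stand for stronger inhibition and higher numbers for weaker inhibition), compound 1 gives 37600 nM and is the only compound of the pair with a plain number. Compound 2 sits at the limit of > 50000 nM in this assay, at which 1 of the 2 values shown sits, which is a limit of the assay rather than a measured number. Compound 1 therefore stands as the one fixed point in this assay, a weak inhibitor.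

Compound 3, `O=C(Nc1cccc(-c2cccs2)c1)C(Cl)Cl`, differs from compound 1 only by thiophen-2-yl in place of furan-3-yl on an aromatic carbon. Going by the values given here, no pair of measured compounds that differ in a single place is available, so the data give no measured step from which the size of this exchange could be read. The step of a 1.1-fold lower number from compound 1 to compound 3 (0.03 log units; within the scatter) is expected to stay within the usual scatter, with no clear direction. Compound 3 is thus expected at 35000 nM, in a range from 15000 nM to 80000 nM.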

Compound 3, half-maximal inhibitory concentration: > 50000 nM
Compound 3 gave a limit, no number; the forecaster's own chance of this, stated with the estimate: 30%; middle value at least 1.4-fold (0.15 log units) away from the limit.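

For the compounds shown here, the first step at this position comes from exchanging furan-3-yl for thiophen-2-yl on the aromatic carbon, and in this assay it reads an at least 1.3-fold higher number from compound 1 to compound 3 (0.12 log units; that floor lies within the scatter). Going by these compounds, the change brought no measurable gain in strength, but the true size of the step stays unknown, since compound 3 carries a limit of the assay and not a number. Compound 1 remains the only compound with a plain number, and compound 3 now joins compound 2 at the same limit: the limit of > 50000 nM in this assay, at which 2 of the 3 values shown sit.

On these data alone, whether thiophen-3-yl, which joins the ring through the same ring position as furan-3-yl, would give a plain number stays open. So does the effect of a small polar group at this place on the shared core, such as an amine or a carboxylic acid.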